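This account rests on a few compounds, and the source may have more. Where it says the series, first, only, none or still open, it means among the compounds named here.

In an ADME assay on Huh-7 cells (Homo sapiens) for cytotoxicity (a lower number here means that less compound is tolerated, a higher number that more compound is tolerated), compound 1 `Cc1ccccc1-c1nn(-c2ccc(F)cc2F)cc1CN1CCN(c2ccccc2)CC1` gives > 20000 nM, which is a limit of the assay and not a number. Compound 2 `Cc1ccccc1-c1nn(Cc2ccc(F)cc2)cc1CNCCN1CCN(C)CC1` likewise gives in this assay > 20000 nM, again a limit. Compound 3 `Cc1ccccc1-c1nn(-c2cc(F)ccc2F)cc1CNCCN1CCN(C)CC1` returns in this assay > 20000 nM, once more only a limit. Among the measured compounds shown here, the single measured step, a step that the two limits leave unreadable from compound 2 to compound 3, therefore has no readable size, and compound 3 stands exactly where the other two values stand, namely at the limit of > 20000 nM in this assay, at which 3 of the 3 values shown sit.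

Compound 4 `Cc1ccc(-n2cc(CNCCN3CCN(C)CC3)c(-c3ccccc3C)n2)c(C)c1` is the next compound to be measured in this assay. It differs from compound 3 in one place: 2,4-dimethylphenyl in place of 2,5-difluorophenyl on an aromatic nitrogen. For the measured compounds named here, no measured step bears directly on this change, and the one step that is available gives no number. Going by the values given here, since every value so far sits at the limit of > 20000 nM in this assay, at which 3 of the 3 values shown sit, compound 4 is expected to behave in the same way, with the step that the limit leaves unreadable from compound 3 to compound 4 expected to show no movement beyond the scatter. Compound 4 is accordingly estimated at 40000 nM in this assay, with a range from 15000 nM to 150000 nM, most likely reported again as a limit.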

Compound 4, half-maximal cytotoxic concentration: > 20000 nM
Compound 4 gave a limit, no number (the forecaster's own chance of this, stated with the estimate: 85%); the middle value is on the limit's open side.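

Compound 4, like compound 2 and compound 3, gives only a limit in this assay, so neither of its steps from those two compounds can be read: the limit of > 20000 nM in this assay, at which 4 of the 4 values shown sit. The compounds shown leave open whether any change on the aromatic nitrogen moves this read-out at all.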